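Swapping methoxy for chloro in compound 1

The source may hold more compounds than are shown below. What is called first, only, known or untested is meant among the compounds shown, and "the series" means these compounds.

In a functional assay on MV4-11 cells (Homo sapiens) for antiproliferative activity, read by CCK-8 assay, with a stated time of 72 h (on this read-out higher numbers stand for weaker inhibition and lower numbers for stronger inhibition), the measured values are
compound 1 (`COc1cccc(-c2cn(C)c(=O)c3[nH]c(C(=O)NCc4ccc(C(=O)Nc5ccccc5N)cc4)cc23)c1`) gives 250 nM
compound 2 (`CC(C)Oc1ccc(C(C)(C)O)cc1-c1cn(C)c(=O)c2[nH]c(C(=O)NCc3ccc(C(=O)NO)cc3)cc12`) gives 350 nM

Compound 1 and compound 2 lie within the usual scatter of each other, so neither stands apart on these numbers. Compound 3 (`Cn1cc(-c2cccc(Cl)c2)c2cc(C(=O)NCc3ccc(C(=O)Nc4ccccc4N)cc3)[nH]c2c1=O`) keeps everything in compound 1 except one group, going from 3-methoxyphenyl to 3-chlorophenyl (chloro in place of methoxy on an aromatic carbon). Within the data shown here, no measured pair shows what this swap does, so in this assay no change beyond the scatter is expected, and neither direction is favoured. The estimated step is small (no change at the digits printed from compound 1 to compound 3 (within the scatter)). Compound 3 is expected at 250 nM (range 90 nM to 700 nM).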

Compound 3, half-maximal inhibitory concentration: 190 nM
Compound 3: middle estimate off by 1.3-fold (0.12 log units), on the high side; the range from low to high includes it.
By their numbers in this assay, from the lowest: compounds 3, 1 and 2 (each within the scatter of the next).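

In this assay this first measured pair for the swap gives a 1.3-fold lower number from compound 1 to compound 3 (0.12 log units; within the scatter), so on this aromatic carbon, chloro can stand in for methoxy with no difference that can be told from the scatter. This holds even though one heavy atom replaces two and the hydrogen-bond acceptor of the methoxy is gone. Nothing measured here offers an explanation for this result. Going by these compounds, what an amine or a carboxylic acid on this same carbon would give stays open, as does whether this swap reads the same on a different parent compound.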